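Methyl on the sulfonamide nitrogen of compound 2

The compounds below may be only part of what the source reports. "The series", "measured", "known", "first", "only" and "open" are said of these compounds alone.

Of the compounds shown here, two have numbers so far. In an assay on CHO cells for displacement of a labelled ligand from prostaglandin D2 receptor 2 (Homo sapiens), read by scintillation counting (a higher number here means a weaker inhibitor, a lower number a stronger inhibitor), compound 1 `CN(C)S(=O)(=O)c1ccc(F)c(C#Cc2cc(Cl)ccc2OCC(=O)O)c1` gives 3.1 nM, while compound 2 `CNS(=O)(=O)c1ccc(C)c(C#Cc2cc(Cl)ccc2OCC(=O)O)c1` gives 10 nM, the higher of the two, a gap beyond the scatter. Compound 3 `Cc1ccc(S(=O)(=O)N(C)C)cc1C#Cc1cc(Cl)ccc1OCC(=O)O` differs from compound 2 in one place: methyl in place of hydrogen on a sulfonamide nitrogen. Among the measured compounds shown here, no measured pair isolates this change, so the expected step from compound 2 to compound 3, estimated as a 1.7-fold lower number from compound 2 to compound 3 (0.22 log units; within the scatter) in this assay, leans toward a lower number yet stays within the scatter. Compound 3 is expected at 6 nM, in a range from 2.5 nM to 15 nM.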

Compound 3, inhibition constant: 5 nM
Compound 3: the middle estimate sits 1.2-fold (0.08 log units) above what was measured; low and high end bracket the measured number.
By their numbers in this assay, from the lowest: compounds 1, 3 and 2 (each within the scatter of the next, the first and the last beyond it).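

Methyl in place of hydrogen on the sulfonamide nitrogen now has a direct reading: this assay gives a 2.0-fold lower number from compound 2 to compound 3 (0.30 log units; within the scatter) and so resolves no difference between methylsulfamoyl and dimethylsulfamoyl. Methyl in place of fluoro on an aromatic carbon gets its first reading too, a 1.6-fold higher number from compound 1 to compound 3 (0.21 log units; within the scatter) and again nothing resolved, so the gap between compound 1 and compound 2 is not traced to one place. No measurement here bears on why either step has its size. Still open, going by these compounds, is whether a longer chain such as ethyl on the sulfonamide nitrogen, or morpholine in place of dimethylamino, holds the number. Chloro or methoxy in place of fluoro on that aromatic carbon is equally open.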